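This account rests on a few compounds, and the source may have more. Where it says the series, first, only, none or still open, it means among the compounds named here.

Measured compounds:
compound 1 `CN1CCN(CCCN(C[C@H]2Cc3ccccc3CN2C)[C@H]2CCCc3cccnc32)CC1` — 536 nM
compound 2 `c1ccc2c(c1)CN[C@@H](CN(CCN1CCNCC1)[C@H]1CCCc3cccnc31)C2` — 553 nM
compound 3 `NC(=O)N1CCN(CCCN(C[C@H]2Cc3ccccc3CN2)[C@H]2CCCc3cccnc32)CC1` — 959 nM

In a functional assay on CCRF-CEM cells for antagonist activity at C-X-C chemokine receptor type 4 (Homo sapiens), read by calcium flux, with stated times of 25 min and 90 s (on this read-out higher numbers stand for weaker inhibition and lower numbers for stronger inhibition), compound 3 carries the highest number of the three, but neither gap sets it apart: the step of a 1.7-fold higher number from compound 2 to compound 3 (0.24 log units; within the scatter) is within the scatter, and the gap to compound 1 is of the same small size. Compound 1 and compound 3 differ in two places, so only their two values can be set side by side, and those two values lie within the scatter of each other.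

The next compound, compound 4 `CN1CCN(CCCN(C[C@H]2Cc3ccccc3CN2)[C@H]2CCCc3cccnc32)CC1`, follows from compound 3 by methyl in place of carbamoyl on an amine nitrogen in a ring. Among the compounds with values here, no measured step covers this exact change. Within the data shown here, the only neighbouring step, a 1.7-fold higher number from compound 2 to compound 3 (0.24 log units; within the scatter), alters a different part of the chain end and is within the scatter. Among the measured compounds shown here, compound 4 also sits one change away from compound 1, which differs from it only on the other amine of the core, and compound 1 in this assay gives 536 nM; that is no measured step, but it shows that a methylpiperazine of this kind has landed in the same band. No shift beyond the scatter is therefore expected, and the step of a 1.5-fold lower number from compound 3 to compound 4 (0.17 log units; within the scatter) is an estimate of little or no change. For compound 4 in this assay the expected value is 650 nM, with a range of 280 nM to 1500 nM.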

Compound 4, half-maximal inhibitory concentration: 125 nM
Compound 4: the middle estimate sits 5.2-fold (0.72 log units) above what was measured; measured number below the stated range.
By their numbers in this assay, from the lowest: compound 4; then compounds 1, 2 and 3 (each within the scatter of the next).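

In this assay, methyl in place of carbamoyl on the amine nitrogen of the six-membered non-aromatic ring with 2 nitrogen gives a 7.7-fold lower number from compound 3 to compound 4 (0.88 log units; beyond the scatter), so the group on this ring nitrogen can move the number beyond the scatter, which the earlier step of a 1.7-fold higher number from compound 2 to compound 3 (0.24 log units; within the scatter) did not show. Two other changes also lead to compound 4 with steps beyond the scatter: a 4.4-fold lower number from compound 2 to compound 4 (0.65 log units; beyond the scatter) comes with (4-methylpiperazin-1-yl)methyl in place of piperazin-1-yl, and a 4.3-fold lower number from compound 1 to compound 4 (0.63 log units; beyond the scatter) comes with hydrogen in place of methyl on the ring amine of the shared core, so a methyl group goes with the lower number on the one ring nitrogen and with the higher number on the other. Nothing available accounts for these steps.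

As far as these compounds go, whether ethyl or acetyl on the ring nitrogen would keep the number as low as methyl remains open. The step from compound 2 also leaves open how much of its size belongs to the methyl group and how much to the chain, a question that (piperazin-1-yl)methyl on the same chain carbon would address.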